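Taking the (1-bromoethenyl)carbonyl group off compound 2

The source may report more compounds than this note shows. Statements on the series, on what has been measured and on what is new or still open speak of the compounds shown alone.

In a functional assay on L1210 cells (Mus musculus) for antiproliferative activity, with a stated time of 48 h (on this read-out higher numbers stand for weaker inhibition and lower numbers for stronger inhibition), compound 1 `C=C(Br)C(=O)Nc1ccc(C(=O)/C=C/c2ccccc2OC)cc1` gives 1700 nM and compound 2 `C=C(Br)C(=O)Nc1ccc(C(=O)/C=C/c2cccc(OC)c2OC)cc1` gives 1100 nM which lies within the scatter of compound 1. Compound 3 `COc1cccc(/C=C/C(=O)c2ccc(N)cc2)c1OC` differs from compound 2 by one change hydrogen in place of (1-bromoethenyl)carbonyl on a nitrogen on an aromatic ring with hydrogen in place of (1-bromoethenyl)carbonyl on a nitrogen on an aromatic ring. Among the compounds with values here, the only measured step of a 1.5-fold lower number from compound 1 to compound 2 (0.19 log units; within the scatter) is a methoxy swap elsewhere and offers no direct guide. Compound 2 at 1100 nM is the starting point, and this much larger change is expected to raise the number. The expected step in this assay is a 14-fold higher number from compound 2 to compound 3 (1.13 log units; beyond the scatter) toward weaker inhibition. Compound 3 is estimated at 15000 nM with a range from 3000 nM to 60000 nM and that range is deliberately wide.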

Compound 3, half-maximal inhibitory concentration: 13000 nM
Compound 3: the middle estimate sits 1.2-fold (0.06 log units) above what was measured, and the stated range covers the measured number.
By their numbers in this assay, from the lowest: compounds 2 and 1 (each within the scatter of the next); then compound 3.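

In this assay, taking the (1-bromoethenyl)carbonyl group off the nitrogen gives a 12-fold higher number from compound 2 to compound 3 (1.07 log units; beyond the scatter), a large move toward weaker inhibition. The earlier methoxy change stayed within the scatter, so this is the first change shown to move the number clearly, and the substituent on this nitrogen matters far more here. Nothing measured here explains the step. The compounds shown leave open whether the bromine or the rest of the group accounts for it. An acetyl or acryloyl group on the same nitrogen would help separate the two.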